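The source may report more compounds than this note shows. Statements on the series, on what has been measured and on what is new or still open speak of the compounds shown alone.

Compound 3 `O=C(/C=C/c1ccc2c(c1)B(O)OC2)c1ccc(Br)cc1` is one of three close relatives examined in an ADME assay on L929 cells (Mus musculus) for cytotoxicity, read by resazurin assay, with a stated time of 72 h; on this read-out higher numbers stand for weaker inhibition and lower numbers for stronger inhibition. In this assay compound 3 gives only a limit, > 10 ug/mL. Compound 1 `O=C(/C=C/c1ccc2c(c1)B(O)OC2)c1ccc(O)cc1` likewise returns a limit in this assay, > 10 ug/mL. Compound 2 `O=C(/C=C/c1ccc2c(c1)B(O)OC2)c1ccc(I)cc1` also returns a limit in this assay, > 10 ug/mL. The steps among these three, a step that the two limits leave unreadable from compound 1 to compound 2, a step that the two limits leave unreadable from compound 1 to compound 3 and a step that the two limits leave unreadable from compound 2 to compound 3, cannot be read, because all three values sit at the limit of > 10 ug/mL in this assay, at which 3 of the 3 values shown sit. Compound 4 `Cc1cccc(C(=O)/C=C/c2ccc3c(c2)B(O)OC3)c1` has not yet been measured in this assay. It differs from compound 3 by 3-methylphenyl in place of 4-bromophenyl on a carbonyl carbon. For the measured compounds named here, no measured step touches the group on the carbonyl carbon; every earlier change sat on an aromatic carbon, and each of those was left unreadable by the limit. The numbers therefore give no indication of a readable step in this assay in either direction, and the expected step that the limit leaves unreadable from compound 3 to compound 4 is taken as none beyond the scatter. Compound 4 is accordingly estimated at 15 ug/mL, with a range from 5 ug/mL to 50 ug/mL, and is expected most likely to be reported once more as a limit.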

Compound 4, half-maximal inhibitory concentration: 8.56 ug/mL
Compound 4: middle estimate off by 1.8-fold (0.24 log units), on the high side; the measured number falls inside the stated range.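

In this assay compound 4 alone of the four gives a number and not a limit, and its change is the only one shown that alters the group on a carbonyl carbon. This gives the change at that position a direction, but only as floors on its size: an at least 1.1-fold lower number from compound 3 to compound 4 (0.06 log units; that floor lies within the scatter), an at least 1.1-fold lower number from compound 2 to compound 4 (0.06 log units; that floor lies within the scatter) and an at least 1.1-fold lower number from compound 1 to compound 4 (0.06 log units; that floor lies within the scatter). The true size of these steps and the steps among compound 1, compound 2 and compound 3 cannot be read, because those three compounds all sit at the same limit: the limit of > 10 ug/mL in this assay, at which 3 of the 4 values shown sit.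

The compounds shown leave open whether the methyl group itself or its place in 3-methylphenyl matters. Also open, going by these compounds, is how an amine or a carboxylic acid on that phenyl ring would read in this assay.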